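Amide nitrogen substituent swap in the tert-butyl pyrazole series

The source may hold more compounds than are shown below. What is called first, only, known or untested is meant among the compounds shown, and "the series" means these compounds.

Compound 2 `CC(C)(C)c1cc(C(=O)Nc2cccnc2)n(Cc2ccccc2)n1` gives 6.3 ug/mL in a physicochemical assay for solubility, read by nephelometry, measured as kinetic solubility, at pH 6.5 (on this read-out lower numbers stand for lower solubility and higher numbers for higher solubility), level with compound 1 `CC(C)(C)c1cc(C(=O)Nc2ccccn2)n(Cc2ccccc2)n1` at 6.3 ug/mL; the step of no change at the digits printed from compound 1 to compound 2 (within the scatter) lies within the scatter. Compound 3 `CC(C)(C)c1cc(C(=O)Nc2cccc(CN)c2)n(Cc2ccccc2)n1` carries the change (3-(aminomethyl)phenyl in place of pyridin-3-yl on an amide-type nitrogen). Within the data shown here, no measured step covers this change; the only step recorded, from one pyridyl to another, is too small and too different to guide it. On the structural change alone, a rise beyond the scatter is expected for compound 3, with the step of a 9.5-fold higher number from compound 2 to compound 3 (0.98 log units; beyond the scatter) as the estimate. Compound 3 is therefore estimated at 60 ug/mL, ranging from 15 ug/mL to 200 ug/mL.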

Compound 3, solubility: 25 ug/mL
The estimate for compound 3 lay 2.4-fold (0.38 log units) above the measured number; the measured number falls inside the stated range.
By their numbers in this assay, from the lowest: compounds 1 and 2 (each within the scatter of the next); then compound 3.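

On the amide-type nitrogen, the change to 3-(aminomethyl)phenyl moves the number in this assay by a 4.0-fold higher number from compound 2 to compound 3 (0.60 log units; beyond the scatter) and by a 4.0-fold higher number from compound 1 to compound 3 (0.60 log units; beyond the scatter) while the swap between the two pyridyl groups moved nothing at the digits printed. This position therefore responds to the substituent, modestly but beyond the scatter. Nothing in hand gives a cause for this rise. As far as these compounds go, the change replaces the ring and adds the aminomethyl group in a single step, and the share of each remains open. A plain phenyl or an aminoethyl chain on that ring would help to separate them.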